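The compounds below may be only part of what the source reports. "The series", "measured", "known", "first", "only" and "open" are said of these compounds alone.

Compound 1 `CCCCCc1cc(-c2cn([C@H]3C[C@H](OC(C)=O)[C@@H](COC(C)=O)O3)c(=O)[nH]c2=O)on1` was tested in a functional assay on PC-3 cells (Homo sapiens) for cytotoxicity, read by sulforhodamine B assay, tested at 10 uM (a higher number here means more inhibition at the concentration tested (going by the name of the read-out), a lower number less inhibition), and gives 93.9%. Compound 2 `CC(=O)OC[C@H]1O[C@@H](n2cc(-c3cn(Cc4ccc(C(C)C)cc4)nn3)c(=O)[nH]c2=O)C[C@@H]1OC(C)=O` gives 91.3% in this assay, a number that lies within the scatter of the value of compound 1, so the two cannot be told apart. Compound 3 `CC(=O)OC[C@H]1O[C@@H](n2cc(-c3cc(-c4ccccc4)no3)c(=O)[nH]c2=O)C[C@@H]1OC(C)=O` has not yet been measured. It differs from compound 1 by phenyl in place of pentyl on an aromatic carbon. Within the data shown here, no measured pair shows this change, so its effect is unknown. Compound 3 is expected to remain close to compound 1, with a step from compound 1 to compound 3 of a number 5.9 percentage points lower from compound 1 to compound 3 (within the scatter) estimated, not beyond the scatter. The estimated value of compound 3 is 88%, within 70% to 97%.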

Compound 3, a percentage reported as inhibition, at one concentration (the size of the read-out at that concentration, not a potency): 85.5%
Compound 3: middle estimate off by 2.5 percentage points, on the high side, within the range that was stated.
By their numbers in this assay, from the lowest: compounds 3, 2 and 1 (each within the scatter of the next).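

Placing phenyl instead of pentyl on the aromatic carbon next to the ring nitrogen gives a number 8.4 percentage points lower from compound 1 to compound 3 (within the scatter) in this assay. Among these compounds, this position therefore accepts either an open pentyl chain or a six-membered aromatic ring without a change that can be told from scatter, which the earlier compounds could not show. No measurement shown explains this result.

As far as these compounds go, it remains open whether an amine, a carboxylic acid or a chain longer than pentyl at this position would give a similar reading. A single concentration also leaves any difference in potency unresolved.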